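A few compounds are considered here, and "the series" means these few. Any claim that something is new, unique, unknown or untested is made for them only; others in the source may bear on it.

Compound 1 `ClCc1ccccc1Cn1cnc2c(Cl)ncnc21` and compound 2 `ClCc1cccc(Cn2cnc3ncnc(Cl)c32)c1` share a core and differ only in where the chloromethyl group sits on the benzyl ring. In a functional assay on NCI-H522 cells (Homo sapiens) for cytotoxicity, read by sulforhodamine B assay, with a stated time of 48 h (a lower number here means a stronger inhibitor of growth, a higher number a weaker inhibitor of growth), compound 1 gives 7240 nM, while compound 2 gives 24000 nM, the higher of the two numbers, a gap that lies beyond the scatter. Compound 3 `ClCc1cccc(Cn2cnc3nc(Cl)nc(Cl)c32)c1` departs from compound 2 by chloro in place of hydrogen on an aromatic carbon. Among the compounds with values here, no measured pair shows what such an added chloro does here, so the step of a 1.6-fold lower number from compound 2 to compound 3 (0.20 log units; within the scatter) is expected to be small, in either direction or none beyond the scatter. Compound 3 is therefore estimated at 15000 nM, within 5000 nM to 50000 nM.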

Compound 3, concentration for total growth inhibition: 3540 nM
Compound 3: middle estimate off by 4.2-fold (0.63 log units), on the high side; the measured number lies below the stated range.
By their numbers in this assay, from the lowest: compound 3; then compound 1; then compound 2.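

In this assay, chloro in place of hydrogen on an aromatic carbon between two ring nitrogen atoms gives a 6.8-fold lower number from compound 2 to compound 3 (0.83 log units; beyond the scatter), a step beyond the scatter. This shows that this position, which carries hydrogen in compound 1 and compound 2, responds to a single added chloro. Nothing measured here accounts for the step.

Going by these compounds, whether an amine or a methoxy group at this position would move the number in the same direction remains open. So does whether the added chloro would act alike with the chloromethyl group placed as in compound 1.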